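Compound 3 to its 4-(trifluoromethyl)benzyl analogue

The compounds below may be only part of what the source reports. "The series", "measured", "known", "first", "only" and "open" are said of these compounds alone.

Values in a functional assay (Platelet, plasma) for inhibition, with Homo sapiens as the target; a lower number here means a stronger inhibitor, a higher number a weaker inhibitor:
- compound 1 `N#Cc1cc2c(nc1N1CCC(C(=O)NS(=O)(=O)Cc3cc(Cl)cc(Cl)c3)CC1)COC2=O`: 30500 nM
- compound 2 `CC(c1ccccc1)S(=O)(=O)NC(=O)C1CCN(c2nc3c(cc2C#N)C(=O)OC3)CC1`: 4160 nM
- compound 3 `N#Cc1cc2c(nc1N1CCC(C(=O)NS(=O)(=O)Cc3ccc(F)cc3F)CC1)COC2=O`: 5200 nM

Compound 3 stands with compound 2 at the low end of these numbers, as a 1.3-fold higher number from compound 2 to compound 3 (0.10 log units; within the scatter) shows, and well clear of compound 1, as a 5.9-fold lower number from compound 1 to compound 3 (0.77 log units; beyond the scatter) shows. The next analogue, compound 4 `N#Cc1cc2c(nc1N1CCC(C(=O)NS(=O)(=O)Cc3ccc(C(F)(F)F)cc3)CC1)COC2=O`, carries 4-(trifluoromethyl)phenyl in place of 2,4-difluorophenyl on a saturated chain carbon bound to a sulfonyl sulfur.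

Going by the values given here, the closest precedent is the exchange of ring substituents at this same place, read in reverse: a 5.9-fold lower number from compound 1 to compound 3 (0.77 log units; beyond the scatter). The exchange leading to compound 2 gives a similar size: a 7.3-fold lower number from compound 1 to compound 2 (0.87 log units; beyond the scatter). Changes to this group have therefore moved the number by a modest amount or not beyond the scatter. Among the compounds with values here, no measured compound carries a trifluoromethyl group, so the direction is weakly supported. Compound 3 lies near the lower end of the measured values, which leaves more room for a rise, and compound 1 at 30500 nM marks how far one ring substitution has gone.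

A modest rise is expected: a 2.1-fold higher number from compound 3 to compound 4 (0.33 log units; beyond the scatter). The estimate for compound 4 is 11000 nM, with an expected range of 4000 nM to 30000 nM.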

Compound 4, half-maximal inhibitory concentration: 15900 nM
Beside the measured number, compound 4's estimate is 1.4-fold (0.16 log units) below it, within the range that was stated.
By their numbers in this assay, from the lowest: compounds 2 and 3 (each within the scatter of the next); then compounds 4 and 1 (each within the scatter of the next).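

Working notes on the sulfonyl substituent, read in this assay: the 4-(trifluoromethyl)benzyl group gives the first step upward from the compound 3 level (a 3.1-fold higher number from compound 3 to compound 4 (0.49 log units; beyond the scatter)), and the same holds against the 1-phenylethyl group (a 3.8-fold higher number from compound 2 to compound 4 (0.58 log units; beyond the scatter)), so the ring substitution pattern at this place can separate two halogen-bearing benzyl groups beyond the scatter. The remaining comparison (a 1.9-fold lower number from compound 1 to compound 4 (0.28 log units; within the scatter)) is within the scatter, which places the 4-(trifluoromethyl)benzyl and 3,5-dichlorobenzyl groups at one level, and the four compounds now fall into two levels, compounds 2 and 3 on the lower-number side and compounds 1 and 4 on the higher-number side. No measurement at hand bears on what sorts these groups into the two levels.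

An unsubstituted benzyl group would give a common reference for all four, since compound 2 differs from the halogen-bearing compounds in both its ring and its chain carbon. Open too, going by these compounds, is how a methoxy group or an amine on the ring, or a longer chain on the sulfonyl sulfur, would read in this assay.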